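Compound 1 and its 3,4,5-trimethoxyphenyl relative

A few compounds are considered here, and "the series" means these few. Any claim that something is new, unique, unknown or untested is made for them only; others in the source may bear on it.

In an ADME assay on J774.A1 cells (Mus musculus) for cytotoxicity, read by MTT assay, with a stated time of 72 h (a lower number here means that less compound is tolerated, a higher number that more compound is tolerated), compound 1 `COc1ccc(-c2cc(-c3ccc(C4NC(=O)c5ccccc5N4)cc3)nc(N)n2)cc1` gives 178000 nM. Compound 3 `CC(C)(C)Nc1nc(Nc2ccc(C3(C)NC(=O)c4ccccc4N3)cc2)nc(NC(C)(C)C)n1` gives 60700 nM, which leaves compound 1 with the higher of these two numbers, by a gap beyond the scatter. Compound 2 `CC(C)c1ccc(C(Nc2ccc(C3(C)NC(=O)c4ccccc4N3)cc2)c2nnnn2C2CCCCC2)cc1` is reported only as a limit, > 400000 nM. Compound 4 `COc1cc(-c2cc(-c3ccc(C4NC(=O)c5ccccc5N4)cc3)nc(N)n2)cc(OC)c1OC` keeps the core of compound 1 but carries 3,4,5-trimethoxyphenyl in place of 4-methoxyphenyl on an aromatic carbon. For the measured compounds named here, no measured pair shows a change of this kind, so the expectation in this assay rests on compound 1 at 178000 nM, and no shift beyond the scatter is expected. The expected change is a 1.2-fold lower number from compound 1 to compound 4 (0.07 log units; within the scatter). Compound 4 is estimated at 150000 nM, within an expected range of 60000 nM to 380000 nM.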

Compound 4, half-maximal cytotoxic concentration: 103000 nM
Compound 4: the middle estimate sits 1.5-fold (0.16 log units) above what was measured, and the stated range covers the measured number.
By their numbers in this assay, from the lowest: compounds 3, 4 and 1 (each within the scatter of the next, the first and the last beyond it). At a limit, above all of these: compound 2.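

For the compounds shown here, this is the first measured step at this position, on an aromatic carbon of the shared core. In this assay, 3,4,5-trimethoxyphenyl in place of 4-methoxyphenyl gives a 1.7-fold lower number from compound 1 to compound 4 (0.24 log units; within the scatter) and so stays within the scatter. At this position, therefore, the assay does not separate the two groups.

Going by these compounds, whether an amine or a carboxylic acid on that phenyl ring would move the number beyond the scatter remains open. No measurement shown bears on why this step has the size it has.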